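A Bromophenyl Ketone in Place of the Vinyl Group

The source may hold more compounds than are shown below. What is called first, only, known or untested is meant among the compounds shown, and "the series" means these compounds.

Compound 1 `CCCc1nnc(SC)n1N1C(=O)c2ccccc2C1=O` and compound 2 `C=CCSc1nnc(-c2cc(OC)c(OC)c(OC)c2)n1N1C(=O)c2ccccc2C1=O` were both examined in a functional assay on HepG2 cells (Homo sapiens) for cytotoxicity, read by MTT assay, with a stated time of 48 h; a higher number here means a weaker inhibitor, a lower number a stronger inhibitor. In this assay compound 1 shows no measurable inhibition and only the limit of the assay is recorded, > 200000 nM. Compound 2 likewise reaches only the limit of this assay, > 200000 nM. Among the compounds with values here, compound 2 therefore stands nowhere on a numerical scale: every value shown so far sits at the same limit, as the limit of > 200000 nM in this assay, at which 2 of the 2 values shown sit, records, and no step between measured compounds can be computed from these data.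

Compound 3 `COc1cc(-c2nnc(SCC(=O)c3ccc(Br)cc3)n2N2C(=O)c3ccccc3C2=O)cc(OC)c1OC` differs from compound 2 in one place, ((4-bromophenyl)carbonyl in place of vinyl on a saturated chain carbon bound to a sulfur). Within the data shown here, since the known values give no measured step to build on, the expected step in this assay from compound 2 to compound 3 is set as an at least 1.3-fold lower number from compound 2 to compound 3 (0.12 log units; that floor lies within the scatter), a small shift toward stronger inhibition that is not expected to go clearly beyond the scatter. On that basis compound 3 is estimated to give about 150000 nM in this assay, within a range from 40000 nM to 500000 nM, with a sizeable chance that only a limit is again reported.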

Compound 3, half-maximal inhibitory concentration: 27700 nM
Compound 3: middle estimate off by 5.4-fold (0.73 log units), on the high side; the whole stated range lies above it.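

Within the data shown here, with compound 3, a measured number appears for the first time in this assay: compound 3 gives 27700 nM. Among these compounds, this shows that a change at this place, on a saturated chain carbon bound to a sulfur, can bring the series off the limit, something the earlier compounds could not show. Placing (4-bromophenyl)carbonyl there in place of vinyl amounts to an at least 7.2-fold lower number from compound 2 to compound 3 (0.85 log units; beyond the scatter), even though the rest of the structure stays the same. As far as these compounds go, that step is only a floor, and its true size remains unknown, because compound 2 is recorded at a limit and not at a number: the limit of > 200000 nM in this assay, at which 2 of the 3 values shown sit.

From the compounds shown here alone, the new group brings in a carbonyl, an aromatic ring and a bromine together, so it remains open which of these parts carries the step, and whether a plain phenyl ketone, a benzyl group without the carbonyl or a chlorine in place of the bromine would do the same. Going by these compounds, it is also open whether the same group would give a comparable step on the core of compound 1, where a propyl chain takes the place of the trimethoxyphenyl group.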